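This account rests on a few compounds, and the source may have more. Where it says the series, first, only, none or still open, it means among the compounds named here.

Compound 1 `Cn1cc(C2CC(c3ccc(Cl)cc3)=NN2C(=O)c2cccnc2)c2cc(Br)ccc21`: 8100 nM
Compound 2 `COc1ccc(C2=NN(C(=O)c3cccnc3)C(c3cn(C)c4ccc(Br)cc34)C2)cc1`: 1560 nM

Going by the values given here, in a functional assay on MCF7 cells (Homo sapiens) for inhibition, read by MTT assay, with a stated time of 48 h (a lower number here means a stronger inhibitor of growth, a higher number a weaker inhibitor of growth), compound 2 gives the lowest of the two numbers so far; its nearest neighbour is compound 1, and the step of a 5.2-fold lower number from compound 1 to compound 2 (0.72 log units; beyond the scatter) lies beyond the scatter. Compound 3 `COc1cc(C2=NN(C(=O)c3cccnc3)C(c3cn(C)c4ccc(Br)cc34)C2)cc(OC)c1OC` is not yet measured. It differs from compound 2 in one place: 3,4,5-trimethoxyphenyl in place of 4-methoxyphenyl on a carbon with a double bond to nitrogen. Among the compounds with values here, the only measured step, a 5.2-fold lower number from compound 1 to compound 2 (0.72 log units; beyond the scatter), concerns the same aromatic ring but a different exchange, so it bears on the present change only loosely; it does show that this ring is a place where a single substituent change moved the number beyond the scatter. A modest move to a lower number is therefore expected for compound 3, as a 1.6-fold lower number from compound 2 to compound 3 (0.19 log units; within the scatter), though a result within the scatter would not surprise. Compound 3 is estimated at 1000 nM, within a range from 300 nM to 3500 nM.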

Compound 3, concentration for 50% growth inhibition: > 10000 nM
Compound 3 ended at the assay's limit; the forecaster's own chance of this, stated with the estimate: 5%; middle value at least 10-fold (1.00 log units) away from the limit.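

In this assay compound 3 gives > 10000 nM, which is a limit of the assay and not a number: the limit of > 10000 nM in this assay, at which 1 of the 3 values shown sits. The exchange of 4-methoxyphenyl for 3,4,5-trimethoxyphenyl at this position gives an at least 6.4-fold higher number from compound 2 to compound 3 (0.80 log units; beyond the scatter), so this ring can also move the number upward, and adding methoxy groups to it did not extend the lower number seen for compound 2. Against the 4-chlorophenyl ring only a floor can be read, an at least 1.2-fold higher number from compound 1 to compound 3 (0.09 log units; that floor lies within the scatter), and it sets no firm order between those two compounds.

The compounds shown do not tell whether the rise needs all three methoxy groups or follows from only one added group. From the compounds shown here alone, how a 3,4-dimethoxyphenyl or a 4-aminophenyl ring would read at this position remains open.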